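The source may report more compounds than this note shows. Statements on the series, on what has been measured and on what is new or still open speak of the compounds shown alone.

Three compounds sharing one core have been compared in a functional assay on DA-3 cells for cytotoxicity against DA-3 cell line (Mus musculus), read by MTT assay; a lower number here means a stronger inhibitor, a higher number a weaker inhibitor. Compound 1 `CC(=O)O[C@@H]1OC(=O)[C@](OC(C)=O)(C(C)=O)[C@@H]1C` gives only a limit of this assay, > 50000 nM. Compound 2 `CC(=O)O[C@@H]1OC(=O)[C@](OC(=O)c2ccccc2)(C(C)=O)[C@@H]1C` gives 3000 nM in this assay. The change from compound 1 to compound 2 is phenyl in place of methyl on a carbonyl carbon and produces an at least 16-fold lower number from compound 1 to compound 2 (1.22 log units; beyond the scatter). Compound 3 `CC(=O)O[C@@H]1OC(=O)[C@@](C)(C(C)=O)[C@@H]1C` gives 9000 nM in this assay, and how its core differs from that of compound 1 is not broken down here. Compound 4 `CC(=O)O[C@@H]1OC(=O)[C@@](C)(C(=O)c2ccccc2)[C@@H]1C` has not been measured; it differs from compound 3 by phenyl in place of methyl on a carbonyl carbon. This is the same kind of change as from compound 1 to compound 2, but not at the same place: there the carbonyl carbon's other neighbour was oxygen next to a carbonyl group, here it is a saturated ring carbon. Resting on the measured at least 16-fold lower number from compound 1 to compound 2 (1.22 log units; beyond the scatter), a step of a 5.0-fold lower number from compound 3 to compound 4 (0.70 log units; beyond the scatter) is expected, smaller than that earlier one. Compound 4 is therefore estimated at 1800 nM in this assay, somewhere between 300 nM and 9000 nM.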

Compound 4, half-maximal inhibitory concentration: 15000 nM
Beside the measured number, compound 4's estimate is 8.3-fold (0.92 log units) below it; measured number outside the range, above it.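

In this assay, the swap of methyl for phenyl on a carbonyl carbon does not carry over from one core to the other: the same change on two cores in this assay, an at least 16-fold lower number (1.22 log units; beyond the scatter) from compound 1 to compound 2 and a 1.7-fold higher number (0.22 log units; within the scatter) from compound 3 to compound 4, at least 27-fold (1.44 log units) apart, beyond the scatter of two such steps

On the core of compound 3 the swap gives a 1.7-fold higher number from compound 3 to compound 4 (0.22 log units; within the scatter), so no real effect can be claimed there. The larger earlier step starts from compound 1, which has only a limit and not a number: the limit of > 50000 nM in this assay, at which 1 of the 4 values shown sits.

These two pairs do not show why the change behaves differently on the two cores, or how it would behave on a third. Going by these compounds, it remains open whether a longer chain or an amine on that carbonyl carbon would move the number on either core.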